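The source may report more compounds than this note shows. Statements on the series, on what has been measured and on what is new or still open speak of the compounds shown alone.

Measured so far in an ADME assay on HepG2 2.2.15 cells (Homo sapiens) for cytotoxicity; on this read-out higher numbers stand for lower toxicity in this test and lower numbers for higher toxicity in this test:
Compound 1 `CC(C)(C)OC(=O)Nc1ncc(C(Oc2ccc3cc(Br)ccc3c2)c2ccc(Cl)cc2)s1` gives > 50000 nM, which is a limit of the assay and not a number.
Compound 2 `O=C(Nc1ncc(C(Oc2ccc3cc(Br)ccc3c2)c2ccc(Cl)cc2)s1)c1ccc(Cl)nc1` gives "not toxic" (no number reported), a description in words with no number reported.

Compound 2 stands on no single number in this assay ; it is reported only as not toxic. Going by the values given here, the one other value shown, that of compound 1, sits at the limit of > 50000 nM in this assay, at which 1 of the 2 values shown sits. Both compounds therefore rest at the non-toxic end of what this assay reports, and the data do not separate one from the other.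

Compound 3 `O=S(=O)(Nc1ncc(C(Oc2ccc3cc(Br)ccc3c2)c2ccc(Cl)cc2)s1)c1ccc(Cl)cc1` has not yet been measured. It differs from compound 2 by (4-chlorophenyl)sulfonyl in place of (6-chloropyridin-3-yl)carbonyl on a nitrogen on an aromatic ring. Among the compounds with values here, no measured step of this kind exists. From compound 2 to compound 3 no shift beyond the usual scatter is expected in this assay , in either direction. In this assay compound 3 is expected to give 50000 nM, with a range from 20000 nM to 100000 nM, and the assay will most likely again report a limit rather than a number.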

Compound 3, half-maximal cytotoxic concentration: "not toxic" (no number reported)
Compound 3 has no reported number here; the estimate stays without a comparison.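

No step can be read between compound 2 and compound 3: in this assay both are reported only in words, without a number. The compounds shown leave open the concentration at which any of them becomes toxic to these cells, and whether (4-chlorophenyl)sulfonyl and (6-chloropyridin-3-yl)carbonyl differ at all on this read-out.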